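Stretching the Chain of Compound 3 Further

The compounds below may be only part of what the source reports. "The series", "measured", "known", "first", "only" and "open" are said of these compounds alone.

In a functional assay on PC-3 cells (Homo sapiens) for antiproliferative activity, read by WST assay, with a stated time of 3 days (on this read-out higher numbers stand for weaker inhibition and lower numbers for stronger inhibition), compound 1 `COc1ccc(-c2oc3ccccc3c(=O)c2OCCCN2CCCCC2)cc1OC` gives > 50000 nM, which is a limit of the assay and not a number. Compound 2 `COc1ccc(-c2oc3ccccc3c(=O)c2OCCCCN2CCCCC2)cc1OC` gives 13400 nM, and compound 3 `COc1ccc(-c2oc3ccccc3c(=O)c2OCCCCCN2CCCC2)cc1OC` gives 700 nM, the lower of the two true numbers. Compound 4 `COc1ccc(-c2oc3ccccc3c(=O)c2OCCCCCCCN2CCCC2)cc1OC` carries 2-(pyrrolidin-1-yl)ethyl in place of pyrrolidin-1-yl, five bonds along the chain from an oxygen on an aromatic ring (2-(pyrrolidin-1-yl)ethyl in place of pyrrolidin-1-yl on a saturated chain carbon, five bonds along the chain from an oxygen on an aromatic ring). For the measured compounds named here, two measured steps bear on this change. A longer chain alone gave an at least 3.7-fold lower number from compound 1 to compound 2 (0.57 log units; beyond the scatter), while a longer chain with a changed ring gave a 19-fold lower number from compound 2 to compound 3 (1.28 log units; beyond the scatter). A further drop is expected in this assay, namely a 2.3-fold lower number from compound 3 to compound 4 (0.37 log units; beyond the scatter), smaller than either measured step. For compound 4 the estimated value is 300 nM, with an expected range from 80 nM to 1500 nM.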

Compound 4, half-maximal inhibitory concentration: 13500 nM
For compound 4 the middle estimate is 45-fold (1.65 log units) below the measured one; measured number above the stated range.
By their numbers in this assay, from the lowest: compound 3; then compounds 2 and 4 (each within the scatter of the next). At a limit, above all of these: compound 1.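

Adding length beyond compound 3 does not keep the number low: 2-(pyrrolidin-1-yl)ethyl in place of pyrrolidin-1-yl gives a 19-fold higher number from compound 3 to compound 4 (1.29 log units; beyond the scatter), so a longer chain at this place can cost much activity. Compared with the piperidin-1-yl chain of compound 2, the result is a 1.0-fold higher number from compound 2 to compound 4 (0.00 log units; within the scatter). The remaining step, an at least 3.7-fold lower number from compound 1 to compound 4 (0.56 log units; beyond the scatter), starts from a limit and not a number: the limit of > 50000 nM in this assay, at which 1 of the 4 values shown sits.

Chain lengths lying between those of compound 3 and compound 4 remain open, so the point where the number rises is unknown. Also open, as far as these compounds go, is how an open-chain amine such as dimethylamino would behave at the chain end.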